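This account rests on a few compounds, and the source may have more. Where it says the series, first, only, none or still open, it means among the compounds named here.

Compound 1 `CCc1ccc(S(=O)(=O)N2CCC(N3CCC(C)CC3)CC2)cc1` gives > 5000 nM in a functional assay on DLD-1 cells (Homo sapiens) for antiproliferative activity, read by CellTiter-Glo, with a stated time of 72 h (on this read-out lower numbers stand for stronger inhibition and higher numbers for weaker inhibition), which is a limit of this assay.
Compound 2 `CC1CCN(C2CCN(S(=O)(=O)c3cccnc3F)CC2)CC1` gives > 5000 nM in this assay, again a limit.

Compound 1 therefore stands only at a limit, not at a number. Within the data shown here, the one measured step, a step that the two limits leave unreadable from compound 1 to compound 2, is unreadable, because of the limit of > 5000 nM in this assay, at which 2 of the 2 values shown sit. Compound 3 `CC1CCN(C2CCN(S(=O)(=O)c3ccc(-c4ccccc4F)cc3)CC2)CC1` differs from compound 1 by 2-fluorophenyl in place of ethyl on an aromatic carbon. Among the measured compounds shown here, no measured step bears readably on this change, so its size and direction cannot be taken from the data. Compound 3 is expected to give 3000 nM, in the range 500 nM to 20000 nM. The step that estimate implies, an at least 1.6-fold lower number from compound 1 to compound 3 (0.22 log units; that floor lies within the scatter), is expected to stay near the limit.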

Compound 3, half-maximal inhibitory concentration: 5 nM
Beside the measured number, compound 3's estimate is 600-fold (2.78 log units) above it; measured number below the stated range.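

In this assay the aromatic carbon para to a large group proves to be a place where the series can gain activity, with an at least 1000-fold lower number from compound 1 to compound 3 (3.00 log units; beyond the scatter) on putting 2-fluorophenyl in place of ethyl. Neither earlier compound gave a number, so this is the first readable step among those shown. Its size is only a floor, since compound 1 stands at a limit: the limit of > 5000 nM in this assay, at which 2 of the 3 values shown sit.

The compounds shown leave open whether the added ring or its fluorine accounts for the step, and how a plain phenyl, an amine or a carboxylic acid would fare at this place.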